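The source may hold more compounds than are shown below. What is called first, only, known or untested is meant among the compounds shown, and "the series" means these compounds.

Compound 2 `COc1ccc(Oc2ccc3c(NCCCNCc4cc(F)ccc4OC)ccnc3c2)cc1` holds the higher of the two solubility numbers: in a physicochemical assay for solubility, with a stated time of 18 h, at pH 7.4 (a higher number here means a more soluble compound, a lower number a less soluble compound), compound 2 gives 14500 nM, while compound 1 `COc1ccc(F)cc1CNCCCNc1ccnc2cc(Cc3ccc(C#N)cc3)ccc12` gives 4200 nM. For the measured compounds named here, the only measured step is a 3.5-fold higher number from compound 1 to compound 2 (0.54 log units; beyond the scatter), a change on an aromatic carbon of the shared core. Compound 3 `COc1ccc(Oc2ccc3c(NCCCNCc4cccc(OC)c4O)ccnc3c2)cc1` differs from compound 2 at another place: 2-hydroxy-3-methoxyphenyl in place of 5-fluoro-2-methoxyphenyl on a saturated chain carbon bound to an amine nitrogen. Going by the values given here, no measured step touches the saturated chain carbon bound to an amine nitrogen, so the step from compound 1 to compound 2 shows only that a swap of one aryl group for another has moved this assay by a modest amount. The entering group carries a hydroxyl and loses the fluorine, and a small rise or no change beyond the scatter is expected, estimated as a 1.4-fold higher number from compound 2 to compound 3 (0.14 log units; within the scatter). For compound 3 the estimate in this assay is 20000 nM, with a range of 8000 nM to 50000 nM.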

Compound 3, solubility: 14500 nM
Compound 3: middle estimate off by 1.4-fold (0.14 log units), on the high side, and the stated range covers the measured number.
By their numbers in this assay, from the lowest: compound 1; then compounds 2 and 3 (each within the scatter of the next).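

With 2-hydroxy-3-methoxyphenyl in place of 5-fluoro-2-methoxyphenyl on a saturated chain carbon bound to an amine nitrogen, this assay shows no change at the digits printed from compound 2 to compound 3 (within the scatter). For the compounds shown here, this is the first measured step at this place, and with the 4-methoxyphenoxy group held constant, the loss of the fluorine and the gain of a hydroxyl leave the read-out unchanged within the scatter. Nothing shown here gives a reason for this result.

From the compounds shown here alone, it remains open whether a larger departure at this place, such as an unsubstituted benzyl, a pyridylmethyl group or a carboxylic acid on the ring, would move the number. Going by these compounds, it is also open whether the same exchange would read the same with 4-cyanobenzyl on the shared core in place of 4-methoxyphenoxy.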